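Isopropoxycarbonyl on the Ring Nitrogen of a Methylsulfanyl Analogue

A few compounds are considered here, and "the series" means these few. Any claim that something is new, unique, unknown or untested is made for them only; others in the source may bear on it.

Compound 1 `COC(=O)C1=C(C)NC(=O)NC1c1cccc([N+](=O)[O-])c1` was tested in an assay on HEK293 cells for antagonist activity at Voltage-dependent L-type calcium channel subunit alpha-1D (Rattus norvegicus), read by FLIPR (a lower number here means a stronger inhibitor, a higher number a weaker inhibitor), where compound 1 gives 18900 nM. Compound 2 `COC(=O)C1=C(C)NC(=O)N(C(=O)OC(C)C)C1c1cccc([N+](=O)[O-])c1` carries isopropoxycarbonyl in place of hydrogen on an amide-type nitrogen in a ring, and in this assay compound 2 gives 4600 nM. That change made a 4.1-fold lower number from compound 1 to compound 2 (0.61 log units; beyond the scatter). Compound 3 `COC(=O)C1=C(C)N=C(SC)NC1c1cccc([N+](=O)[O-])c1` differs from compound 1 in its core; the difference between the two cores is not broken down here. In this assay compound 3 gives 10600 nM, which lies within the scatter of the number for compound 1 and beyond the scatter from the number for compound 2.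

Compound 4 `COC(=O)C1=C(C)N=C(SC)N(C(=O)OC(C)C)C1c1cccc([N+](=O)[O-])c1` has not yet been measured. Within the data shown here, it carries isopropoxycarbonyl in place of hydrogen on an amine nitrogen in a ring, the same kind of change as the one from compound 1 to compound 2. The two places are not the same word for word: in compound 3 the nitrogen is an amine nitrogen in a ring rather than an amide-type nitrogen, and it is next to the ring atom that bears a methylsulfanyl group, which compound 1 does not have. Among the measured compounds shown here, a step of about the earlier size is expected because a 4.1-fold lower number from compound 1 to compound 2 (0.61 log units; beyond the scatter) is the only measured instance of this kind of change. The expected step is a 4.1-fold lower number from compound 3 to compound 4 (0.61 log units; beyond the scatter). This estimate rests on compound 3 with 10600 nM and on one step alone, so its range is wide. Compound 4 is therefore estimated at 2600 nM, between 1000 nM and 7000 nM.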

Compound 4, half-maximal inhibitory concentration: 5580 nM
Estimate against measurement, compound 4: 2.1-fold (0.33 log units) below, and the stated range covers the measured number.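

In this assay, isopropoxycarbonyl in place of hydrogen on the amine nitrogen in the ring of the methylsulfanyl core gave a 1.9-fold lower number from compound 3 to compound 4 (0.28 log units; within the scatter), so on this core alone the change cannot be told apart from the ordinary spread of repeated measurements. Set beside the step on the core of compound 1, the new step does not differ from it by more than such measurements allow: the same change on two cores in this assay, a 4.1-fold lower number (0.61 log units; beyond the scatter) from compound 1 to compound 2 and a 1.9-fold lower number (0.28 log units; within the scatter) from compound 3 to compound 4, 2.2-fold (0.34 log units) apart, within the scatter of two such steps. Among these compounds, this shows that the two results are compatible with the change carrying over from one core to the other at a similar size, but it does not show that the size is conserved, since the comparison rests on only two steps, one of them beyond the scatter and the other within it, and a gap within the scatter does not establish that the steps are equal.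

The compounds shown leave open whether an acetyl group, an ethoxycarbonyl group or a longer alkyl chain on the same ring nitrogen would give steps of similar size on both cores. They also leave open whether the step would hold on a core bearing an amine in place of the methylsulfanyl group.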